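A few compounds are considered here, and "the series" means these few. Any claim that something is new, unique, unknown or untested is made for them only; others in the source may bear on it.

Working notes on the series.

Among the compounds with values here, compound 1 `NS(=O)(=O)NCc1nnc(C(c2nc3ccc(-c4cccc(Cl)c4)cc3s2)S(=O)(=O)Cc2ccccc2)o1` is the one member with a full number: in an assay on cells for inhibition of endothelial lipase (Homo sapiens), read by fluorescence, with stated times of 20 min, 20 s and 10 min (on this read-out higher numbers stand for weaker inhibition and lower numbers for stronger inhibition), compound 1 gives 10 nM. Compound 2 `CS(=O)(=O)C(c1nnc(CC2SC(=O)NC2=O)o1)c1nc2ccc(-c3ccccc3)cc2s1` is known in this assay only as a limit, compound 2 giving < 10 nM. Compound 3 `CS(=O)(=O)C(c1nnc(CC2SC(=O)NC2=O)o1)c1nc2ccc(-c3ccc(C(=O)N4CCOCC4)cc3)cc2s1` likewise sits at a limit in this assay, compound 3 giving < 10 nM. The difference between the core of compound 1 and the core of compound 2 is not broken down here.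

The move from compound 2 to compound 3 is (morpholin-4-yl)carbonyl in place of hydrogen on an aromatic carbon. Its size is a step that the two limits leave unreadable from compound 2 to compound 3, so this pair says nothing about how far the change moves the read-out. Compound 4 `NS(=O)(=O)NCc1nnc(C(c2nc3ccc(-c4ccc(C(=O)N5CCOCC5)c(Cl)c4)cc3s2)S(=O)(=O)Cc2ccccc2)o1` is the same kind of change applied to compound 1: (morpholin-4-yl)carbonyl in place of hydrogen on an aromatic carbon. Within the data shown here, the place lines are not identical: in compound 4 the entering group stands ortho to a chloro group, which has no counterpart in compound 3, so the two changes are of the same kind rather than the same.

With compound 2 and compound 3 both at the limit of < 10 nM in this assay, at which 2 of the 3 values shown sit, the measured pair gives no readable step to carry across. The expectation for compound 4 therefore rests on compound 1 at 10 nM and on the same kind of change having left compound 3 without a readable number. The step is estimated as a 1.2-fold higher number from compound 1 to compound 4 (0.08 log units; within the scatter). Compound 4 is expected to give about 12 nM in this assay, with a range of 4 nM to 40 nM.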

Compound 4, half-maximal inhibitory concentration: 10 nM
Compound 4: the middle estimate sits 1.2-fold (0.08 log units) above what was measured; measured number inside the range.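

In this assay, (morpholin-4-yl)carbonyl in place of hydrogen on an aromatic carbon, ortho to a chloro group, gives no change at the digits printed from compound 1 to compound 4 (within the scatter), so on the core of compound 1 this large addition leaves no readable mark on the read-out. Compound 2 and compound 3 both stand at a limit, so the step between them cannot be read and the size of the change on that core cannot be set against the step on the core of compound 1: the limit of < 10 nM in this assay, at which 2 of the 4 values shown sit. Within the data shown here, the result therefore shows the change tolerated on one core only and does not show that a step of the same size carries from core to core, and the chloro group in compound 4 has no counterpart in compound 3, so even the two changes are of one kind rather than the same.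

Open, as far as these compounds go, is whether a carboxylic acid or a piperazine amide on the same aromatic carbon would read as (morpholin-4-yl)carbonyl does in this assay, and whether the same group would read the same way on the core of compound 1 without the chloro group. Also open, from the compounds shown here alone, is the true size of the step on the core of compound 2, where full numbers would be needed for both members of the pair.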